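Methoxy Added to a Diamidine: Expecting Compound 4

The compounds below may be only part of what the source reports. "The series", "measured", "known", "first", "only" and "open" are said of these compounds alone.

Compound 1, `N=C(N)c1ccc(-c2cc3cc(C(=N)N)ccc3o2)cc1`, gives 1900 nM in an ADME assay on L6 cells (Rattus norvegicus) for cytotoxicity; a lower number here means a stronger inhibitor, a higher number a weaker inhibitor.
Compound 2, `CC(C)NC(=N)c1ccc(-c2cc3cc(C(=N)NC(C)C)ccc3o2)cc1`, sits at a limit of this assay, > 198000 nM.
Compound 3, `COc1cc(C(=N)NC(C)C)cc2cc(-c3ccc(C(=N)NC(C)C)cc3)oc12`, sits at a limit of this assay, > 190000 nM.

Only compound 1 yields a number; the other two values are limits, as the limit of > 198000 nM in this assay, at which 1 of the 3 values shown sits, and the limit of > 190000 nM in this assay, at which 1 of the 3 values shown sits, record. The difference between the core of compound 1 and the core of compound 2 is not broken down here. From compound 2 to compound 3 the change is methoxy in place of hydrogen on an aromatic carbon, and it made a step that the two limits leave unreadable from compound 2 to compound 3. Compound 4, `COc1cc(C(=N)N)ccc1-c1cc2cc(C(=N)N)ccc2o1`, is not yet measured; it differs from compound 1 by methoxy in place of hydrogen on an aromatic carbon. This is the same kind of change, though the place differs: here it is ortho to a large group and meta to a group of 3 heavy atoms, whereas before it was part of a fused or bridged system of two rings, ortho and meta to a fused ring and meta to a group of 6 heavy atoms. With the measured step unreadable, the expectation rests on compound 1, which gives 1900 nM. Compound 4 is expected to give about 2500 nM, within 700 nM to 9000 nM. That estimate means an expected step of a 1.3-fold higher number from compound 1 to compound 4 (0.12 log units; within the scatter).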

Compound 4, half-maximal inhibitory concentration: 157000 nM
Compound 4: middle estimate off by 63-fold (1.80 log units), on the low side, outside the stated range (above it).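

In this assay, methoxy in place of hydrogen on an aromatic carbon, ortho to a large group and meta to a group of 3 heavy atoms, gives an 83-fold higher number from compound 1 to compound 4 (1.92 log units; beyond the scatter), so on this core and at this place the change is large. The same kind of change at a different place, from compound 2 to compound 3, cannot be read since both values are limits, so nothing here shows whether the size of the step carries from one core to another. Nothing shown accounts for the size of the step.

Still open, from the compounds shown here alone, is whether hydroxy or ethoxy at the same place on compound 1 would raise the number as far as methoxy does. Also open, going by these compounds, is how much the step depends on the place of the methoxy on this core.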